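The compounds below may be only part of what the source reports. "The series", "measured", "known", "first", "only" and "open" are said of these compounds alone.

Compound 2 `COc1ccc(-c2cc3ccccc3c(-c3cccc(OC)c3)n2)cc1` gives 43.2% in an assay on isolated protein for inhibition of DNA topoisomerase 1 (Homo sapiens), with a stated time of 30 min, tested at 100 uM (on this read-out lower numbers stand for a weaker effect and higher numbers for a stronger effect at the one concentration tested), the higher of the two numbers obtained so far; compound 1 `COc1ccc(-c2cc3ccccc3c(-c3cccc(O)c3)n2)cc1` gives 9.4% in this assay. Among the compounds with values here, the only measured step, a number 33.8 percentage points higher from compound 1 to compound 2 (beyond the scatter), concerns the methyl on the oxygen and does not touch the change now at hand. Compound 3 `COc1ccc(-c2cc3ccccc3c(-c3ccc(OC)cc3)n2)cc1` differs from compound 2 by 4-methoxyphenyl in place of 3-methoxyphenyl on an aromatic carbon. Within the data shown here, no measured step moves a methoxy around this ring, so the direction is open and a step of a number 3.2 percentage points lower from compound 2 to compound 3 (within the scatter) is expected, within the usual scatter. Compound 3 is estimated at 40%, with a range from 20% to 60%.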

Compound 3, a percentage reported as inhibition, at one concentration (the size of the read-out at that concentration, not a potency): 0%
The estimate for compound 3 lay 40 percentage points above the measured number; the whole stated range lies above it.
By their numbers in this assay, from the lowest: compounds 3 and 1 (each within the scatter of the next); then compound 2.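

In this assay, 4-methoxyphenyl in place of 3-methoxyphenyl on this aromatic carbon next to the ring nitrogen costs the whole signal (a number 43.2 percentage points lower from compound 2 to compound 3 (beyond the scatter)), so the read-out here depends on where the methoxy sits on the ring, not only on the methyl on the oxygen. Compound 3 does not separate from compound 1 (a number 9.4 percentage points lower from compound 1 to compound 3 (within the scatter)), which leaves the 3-methoxyphenyl group of compound 2 alone beyond the scatter among the three. No supporting data bear on this difference.

From the compounds shown here alone, whether an amine or a carboxylic acid in place of the methoxy of 3-methoxyphenyl, or a longer chain on its oxygen, would keep the read-out of compound 2 remains open.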